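Swapping the acyloxyalkyl group on a quinazoline kinase inhibitor

The compounds below may be only part of what the source reports. "The series", "measured", "known", "first", "only" and "open" are said of these compounds alone.

Measured compounds:
Compound 1, `CCOC(=O)N1CCN(C(=O)c2nc(Nc3cc(C4CC4)[nH]n3)c3cc(Cl)ccc3n2)C[C@H]1C`, in an assay for inhibition of serine/threonine-protein kinase PAK 4 (Homo sapiens), read by FRET and Z'-LYTE, with a stated time of 60 min, tested at 5 uM, in the presence of a further agent that is not named here (a lower number here means a weaker effect, a higher number a stronger effect of the compound at the concentration tested), compound 1 gives 79.2%.
Compound 2, `CC(OC(=O)N1CCN(C(=O)c2nc(Nc3cc(C4CC4)[nH]n3)c3cc(Cl)ccc3n2)C[C@H]1C)OC(=O)C(C)(C)C`, in this assay compound 2 gives 23.6%.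

Among the measured compounds shown here, compound 2 stands lowest of the two numbers measured so far; its nearest neighbour is compound 1, and the step of a number 55.6 percentage points lower from compound 1 to compound 2 (beyond the scatter) is large. That step shows that putting ((tert-butyl)carbonyl)oxy on a saturated chain carbon in place of hydrogen costs a great deal of inhibition.

Compound 3, `CC(C)C(=O)OCOC(=O)N1CCN(C(=O)c2nc(Nc3cc(C4CC4)[nH]n3)c3cc(Cl)ccc3n2)C[C@H]1C`, has not yet been measured. It differs from compound 2 by ((isopropylcarbonyl)oxy)methyl in place of 1-(((tert-butyl)carbonyl)oxy)ethyl on an oxygen next to a carbonyl group. For the measured compounds named here, the only step that bears on this is the one from compound 1 to compound 2, which shows how much a group of this kind on that oxygen reduces the read-out. Compound 3 still carries such a group, though a different one, so an estimate for compound 3 places it between the two measured values, nearer compound 2: an expected 35%, in the range 12% to 60%, an expected step of a number 11.4 percentage points higher from compound 2 to compound 3 (beyond the scatter).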

Compound 3, a percentage reported as inhibition, at one concentration (the size of the read-out at that concentration, not a potency): 51.6%
Beside the measured number, compound 3's estimate is 16.6 percentage points below it; the range from low to high includes it.
By their numbers in this assay, from the lowest: compound 2; then compound 3; then compound 1.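

In this assay, the group on the oxygen next to a carbonyl group matters in its detail: ((isopropylcarbonyl)oxy)methyl in place of 1-(((tert-butyl)carbonyl)oxy)ethyl gives a number 28 percentage points higher from compound 2 to compound 3 (beyond the scatter), so the loss seen earlier is not a fixed price for every group of this kind. Part of that loss remains, however, with a number 27.6 percentage points lower from compound 1 to compound 3 (beyond the scatter), which places the smaller group partway between the two earlier compounds. Nothing available explains either step.

The step from compound 2 to compound 3 changes two things at once, the tert-butyl to isopropyl and the ethyl to methyl, so the gain cannot be assigned to either alone. As far as these compounds go, a ((tert-butyl)carbonyl)oxy)methyl group or a 1-((isopropylcarbonyl)oxy)ethyl group on the same oxygen would separate the two, and how either would read remains open.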